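The compounds below may be only part of what the source reports. "The series", "measured", "known", "first", "only" and "open" are said of these compounds alone.

Compound 3 `COC(=O)c1cccc(NC(=O)Nc2cc(C)nc3ccccc23)c1` gives the highest of the three numbers in an ADME assay for permeability, using PAMPA, at pH 7.4 (a lower number here means that the compound crosses the layer more slowly, a higher number that the compound crosses the layer faster), at 746 10^-6 cm/s. Compound 1 `Cc1cc(NC(=O)Nc2ccccc2N)c2ccccc2n1` gives 300 10^-6 cm/s in this assay, and compound 2 `Cc1cc(NC(=O)Nc2cccc(C(N)=O)c2)c2ccccc2n1` gives 2 10^-6 cm/s. For the measured compounds named here, the one measured step at the same position, a 370-fold higher number from compound 2 to compound 3 (2.57 log units; beyond the scatter), was large. Compound 4 `Cc1cc(NC(=O)Nc2cccc(Cl)c2)c2ccccc2n1` differs from compound 3 by chloro in place of methoxycarbonyl on an aromatic carbon. Going by the values given here, no measured step swaps an ester for a halogen, so only the value of compound 3 anchors the guess. A modest step of a 1.1-fold higher number from compound 3 to compound 4 (0.06 log units; within the scatter) is expected, most likely upward or flat, since compound 3 already stands high at 746 10^-6 cm/s. Compound 4 is therefore estimated at 850 10^-6 cm/s, within 350 10^-6 cm/s to 1600 10^-6 cm/s.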

Compound 4, apparent permeability: 566 10^-6 cm/s
Beside the measured number, compound 4's estimate is 1.5-fold (0.18 log units) above it, within the range that was stated.
By their numbers in this assay, from the lowest: compound 2; then compounds 1, 4 and 3 (each within the scatter of the next, the first and the last beyond it).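

Replacing methoxycarbonyl with chloro gives a 1.3-fold lower number from compound 3 to compound 4 (0.12 log units; within the scatter) in this assay, so this position tolerates two quite different groups with no clear change in the number. Compound 2 remains the exception among these compounds: carbamoyl to chloro gives a 280-fold higher number from compound 2 to compound 4 (2.45 log units; beyond the scatter) on the same aromatic carbon. A change at the other end of the molecule gives a 1.9-fold higher number from compound 1 to compound 4 (0.28 log units; within the scatter) and likewise stays small. Nothing measured here explains these numbers. As far as these compounds go, whether a carboxylic acid or a primary amine on this carbon would fall as low as compound 2 remains open, as does whether fluoro or methyl would match chloro.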